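The source may hold more compounds than are shown below. What is called first, only, known or untested is meant among the compounds shown, and "the series" means these compounds.

Measured compounds:
Compound 1 `O=C1/C(=C/c2ccccc2)Cc2cc(O)ccc21` gives 1940 nM
Compound 2 `O=C1/C(=C/c2ccc(F)cc2)Cc2cc(O)ccc21` gives 679 nM
Compound 3 `N#Cc1ccc(/C=C2\Cc3cc(O)ccc3C2=O)cc1` gives 2080 nM

All three share one core and differ only in the group on the outer aromatic ring, and all were tested in an assay on isolated protein for inhibition of Amine oxidase [flavin-containing] A (Homo sapiens), read by fluorescence and spectrophotometry, with a stated time of 20 min; on this read-out lower numbers stand for stronger inhibition and higher numbers for weaker inhibition. Compound 3, carrying a cyano group there, sits at the weak end of this small set: its step from compound 1, a 1.1-fold higher number from compound 1 to compound 3 (0.03 log units; within the scatter), lies within the scatter, so the two cannot be told apart, whereas a 3.1-fold higher number from compound 2 to compound 3 (0.49 log units; beyond the scatter) is modest but beyond it, the fluoro compound giving the lower number.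

Compound 4 `CN(C)c1ccc(/C=C2\Cc3cc(O)ccc3C2=O)cc1` has not yet been measured in this assay. It differs from compound 3 by dimethylamino in place of cyano on an aromatic carbon. Within the data shown here, the steps that bear on this position are a 1.1-fold higher number from compound 1 to compound 3 (0.03 log units; within the scatter) and a 3.1-fold higher number from compound 2 to compound 3 (0.49 log units; beyond the scatter); neither involves a dimethylamino group, so there is no direct evidence for how this group behaves here. Hydrogen and cyano gave numbers within the scatter of each other, and only fluoro moved the number, modestly. On that basis a step of a 1.4-fold lower number from compound 3 to compound 4 (0.14 log units; within the scatter) is expected, within or near the scatter, with no firm direction. Compound 4 is therefore estimated at 1500 nM, with a range of 400 nM to 6000 nM.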

Compound 4, half-maximal inhibitory concentration: 1720 nM
Beside the measured number, compound 4's estimate is 1.1-fold (0.06 log units) below it; low and high end bracket the measured number.
By their numbers in this assay, from the lowest: compound 2; then compounds 4, 1 and 3 (each within the scatter of the next).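

The step of a 1.2-fold lower number from compound 3 to compound 4 (0.08 log units; within the scatter) and the step of a 1.1-fold lower number from compound 1 to compound 4 (0.05 log units; within the scatter) both stay within the scatter, so in this assay hydrogen, cyano and dimethylamino cannot be told apart at this position, a result that extends what the earlier pair of hydrogen and cyano showed to a group with more heavy atoms. Among these compounds, the step of a 2.5-fold higher number from compound 2 to compound 4 (0.40 log units; beyond the scatter) is modest but beyond the scatter, so compound 2, with its fluoro group, holds the lowest number of the four and remains the only one whose number sets it apart from all the others. Nothing in the data shown offers an explanation for this pattern.

Going by these compounds, with fluoro as the only halogen here, it stays open whether chloro or bromo at this position would give a number like that of compound 2, or whether the fluoro result stands alone. On these data alone, it is also open what a methoxy group, a carboxylic acid or a longer chain would do here, and whether these groups would behave alike on another carbon of the same ring.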